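Adding a Chlorine to Compound 3: Expected Growth Inhibition

The source may report more compounds than this note shows. Statements on the series, on what has been measured and on what is new or still open speak of the compounds shown alone.

Compound 1 `O=C(/C(=C/c1ccc(Cl)cc1)CCl)c1ccccc1` and compound 2 `O=C(/C(=C/c1ccc(Cl)cc1Cl)CCl)c1ccccc1` share one core; compound 3 `CC(=O)OC/C(=C\C1CCCCC1)C(=O)c1ccccc1` and compound 4 `CC(=O)OC/C(=C\C1CCCCC1)C(=O)c1ccc(Cl)cc1` share another, and the difference between the two cores is not broken down here. In a functional assay on WiDr cells (Homo sapiens) for inhibition, read by sulforhodamine B assay, with a stated time of 48 h (on this read-out higher numbers stand for weaker inhibition of growth and lower numbers for stronger inhibition of growth), compound 1 gives 19000 nM and compound 2 gives 13000 nM, while compound 3 gives 21000 nM. The change from compound 1 to compound 2 chloro in place of hydrogen on an aromatic carbon produced a 1.5-fold lower number from compound 1 to compound 2 (0.16 log units; within the scatter). The change from compound 3 to compound 4 chloro in place of hydrogen on an aromatic carbon is the same kind of change, though the place differs: in compound 2 the chloro is ortho to a large group and meta to a chloro group, in compound 4 it is para to a large group. Because a 1.5-fold lower number from compound 1 to compound 2 (0.16 log units; within the scatter) was small, the step of a 1.4-fold lower number from compound 3 to compound 4 (0.15 log units; within the scatter) is expected to be small as well. For compound 4 in this assay the estimate is 15000 nM, between 7000 nM and 35000 nM.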

Compound 4, concentration for 50% growth inhibition: 21000 nM
For compound 4 the middle estimate is 1.4-fold (0.15 log units) below the measured one; measured number inside the range.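

In this assay, putting chloro in place of hydrogen on an aromatic carbon of the second core leaves the number unmoved (no change at the digits printed from compound 3 to compound 4 (within the scatter)). Two pairs cannot show that this change is without effect on every core in the series, and the chloro does not stand in the same place in the two pairs. What they do show is that, in these two cases, the change carries from one core to the other as a step too small to read, and the two steps agree: the same change on two cores in this assay, a 1.5-fold lower number (0.16 log units; within the scatter) from compound 1 to compound 2 and no change at the digits printed (within the scatter) from compound 3 to compound 4, 1.5-fold (0.16 log units) apart, within the scatter of two such steps

The compounds shown leave open what a group other than chloro would do at the position para to a large group, such as an amine or a carboxylic acid. They also leave open whether a longer chain there would give a step large enough to read.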